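Chloro for Trifluoromethyl on a Fused Core

This account rests on a few compounds, and the source may have more. Where it says the series, first, only, none or still open, it means among the compounds named here.

The series is compared in a physicochemical assay for lipophilicity, at pH 7.4; a lower number here means a more polar compound, a higher number a more lipophilic compound. Compound 1, `CCOc1cc2[nH]c(Cc3nn(CC(=O)N4CCOCC4)c(=O)c4ccccc34)nc2cc1Cl`, gives 3.32. Compound 2, `CC(C(=O)O)c1nn(Cc2cn3cc(OCC4CC4)c(C(F)(F)F)cc3n2)c2ccccc2c1=O`, gives 2.99. Compound 3, `COc1ccc(Cl)cc1NC(=O)Cc1nn(CC(=O)O)c(=O)c2ccccc12`, gives 1.9. Among these three numbers compound 2 takes the second highest place: compound 1 sits above it by a margin beyond the scatter, and compound 3 sits below it by a clearly larger margin, also beyond the scatter. Going by the values given here, no two of the measured compounds differ in a single place, so no measured step is available to lean on.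

The unmeasured compound 4, `CC(C(=O)O)c1nn(Cc2cn3cc(OCC4CC4)c(Cl)cc3n2)c2ccccc2c1=O`, is compound 2 with one change: chloro in place of trifluoromethyl on an aromatic carbon. The replaced group counts four heavy atoms and the entering one a single chlorine, with no change in donors, acceptors or charge, and the position on the fused core is otherwise untouched.

The step from compound 2 to compound 4 is expected to be small and downward, a number 0.24 log units lower from compound 2 to compound 4 (within the scatter), and it may not exceed the scatter of the assay. Compound 4 is therefore expected to give 2.75 in this assay, with a likely range from 2.4 to 3.1.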

Compound 4, distribution coefficient: 2.44
Beside the measured number, compound 4's estimate is 0.31 log units above it; the measured number falls inside the stated range.
By their numbers in this assay, from the lowest: compound 3; then compound 4; then compound 2; then compound 1.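

In this assay the exchange gives a number 0.55 log units lower from compound 2 to compound 4 (beyond the scatter) on an aromatic carbon ortho to a cyclopropylmethoxy group, so chloro in place of trifluoromethyl at this position moves the number by a measurable amount. Compound 1 and compound 3 differ from compound 2 in more than one place, so they could not isolate this position; this pair does, with the rest of the structure, including the carboxylic acid side chain, held the same. Nothing among the data accounts for the size or direction of this step.

The compounds shown leave open whether chloro in place of trifluoromethyl would move the number in the same direction and by a similar size on the core of compound 1, or in a compound whose carboxylic acid is replaced by an amide. They also leave open where a methyl, a bromo or a nitrile on this same aromatic carbon would fall relative to compound 2 and compound 4.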